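Lengthening the acid chain of compound 3

This account rests on a few compounds, and the source may have more. Where it says the series, first, only, none or still open, it means among the compounds named here.

In a physicochemical assay for solubility, read by spectrophotometry, using the shake flask method, with a stated time of 48 h, at pH 6.5 (a higher number here means a more soluble compound, a lower number a less soluble compound), compound 3 `O=C(O)COc1ccc2nc(-c3cn(-c4ccc(O)c(F)c4)nn3)ccc2c1` gives 37 ug/mL, the middle of three numbers. The highest number comes from compound 1 `O=C(O)COc1ccc2nc(-c3cn(-c4ccc(O)cc4)nn3)ccc2c1` with 365 ug/mL. The lowest comes from compound 2 `NCCOCCOc1ccc2nc(-c3cn(-c4ccc(O)c(F)c4)nn3)ccc2c1` with 9.1 ug/mL. Compound 4 `O=C(O)CCCOc1ccc2nc(-c3cn(-c4ccc(O)c(F)c4)nn3)ccc2c1` carries 2-carboxyethyl in place of carboxy on a saturated chain carbon bound to an oxygen on an aromatic ring. Within the data shown here, the one measured step at this place, a 4.1-fold higher number from compound 2 to compound 3 (0.61 log units; beyond the scatter), was modest, as was the fluoro step a 9.9-fold lower number from compound 1 to compound 3 (0.99 log units; beyond the scatter). Neither shows a simple lengthening of the acid chain, so the evidence is indirect. In this assay the expected result is a 1.9-fold lower number from compound 3 to compound 4 (0.27 log units; within the scatter), a small move to a lower number. Compound 4 is estimated at 20 ug/mL, with an expected range of 6 ug/mL to 60 ug/mL.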

Compound 4, solubility: 19.2 ug/mL
For compound 4 the middle estimate is 1.0-fold (0.02 log units) above the measured one, within the range that was stated.
By their numbers in this assay, from the lowest: compound 2; then compounds 4 and 3 (each within the scatter of the next); then compound 1.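

In this assay, among these compounds, the acid chain itself can now be read for the first time: carboxymethoxy gives way to 3-carboxypropoxy with a 1.9-fold lower number from compound 3 to compound 4 (0.28 log units; within the scatter), so this lengthening leaves the number inside the scatter. With the longer acid chain in place, the comparison with the amine-bearing chain of compound 2 still gives a 2.1-fold higher number from compound 2 to compound 4 (0.32 log units; beyond the scatter). No measurement shown here accounts for either step. From the compounds shown here alone, whether a longer chain still, or an amide in place of the carboxylic acid, would behave alike remains open. So does whether the same lengthening reads the same on compound 1, which lacks the fluoro group.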